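Adding a phenyl to a sulfone analogue: what to expect

A few compounds are considered here, and "the series" means these few. Any claim that something is new, unique, unknown or untested is made for them only; others in the source may bear on it.

Measured compounds:
compound 1 `O=C1CC(c2ccccc2)Cc2[nH]c(=O)c(C(=O)c3ccccc3)cc21` — 0%
compound 2 `O=C1CCCc2[nH]c(=O)c(S(=O)(=O)c3ccccc3)cc21` — 0%

Of the compounds shown here, two sharing one core have been tested in an assay on isolated protein for inhibition of 3',5'-cyclic-AMP phosphodiesterase 4A (Cavia porcellus), read by cAMP accumulation, tested at 1 uM; on this read-out higher numbers stand for a stronger effect at the one concentration tested and lower numbers for a weaker effect. Compound 1 carries a benzoyl group and a phenyl on a saturated ring carbon; in this assay compound 1 gives 0%. Compound 2 carries a phenylsulfonyl group instead of the benzoyl group and lacks the phenyl on the saturated ring carbon; in this assay compound 2 gives 0%. Compound 2 therefore stands level with compound 1 at the digits shown, and the two values lie within the scatter of one another.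

Compound 3 `O=C1CC(c2ccccc2)Cc2[nH]c(=O)c(S(=O)(=O)c3ccccc3)cc21` is not yet measured. It differs from compound 2 in one place: phenyl in place of hydrogen on a saturated ring carbon. Among the measured compounds shown here, no step between measured compounds tells what this change does on its own. Still, compound 1, which already carries this phenyl, shows no measurable inhibition, so nothing in the data points to a gain. The step from compound 2 to compound 3 is expected to be no change at the digits printed from compound 2 to compound 3 (within the scatter), that is, no change beyond the scatter. For compound 3 the expected value in this assay is 0%, with a likely range from -10% to 10%.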

Compound 3, a percentage reported as inhibition, at one concentration (the size of the read-out at that concentration, not a potency): 0%
Beside the measured number, compound 3's estimate shows no gap at the digits printed, and the stated range covers the measured number.
By their numbers in this assay, from the lowest: compounds 1, 2 and 3 (each within the scatter of the next).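

In this assay, phenyl in place of hydrogen on a saturated ring carbon now has a step of its own, and it reads no change at the digits printed from compound 2 to compound 3 (within the scatter) on the shared core. Phenylsulfonyl in place of benzoyl on an aromatic carbon can now also be read alone, with that phenyl present in both compounds, and it gives no change at the digits printed from compound 1 to compound 3 (within the scatter), so neither single change brings out measurable inhibition at the one concentration tested. No outside information bears on this result.

Since all three compounds show no inhibition, these steps cannot tell whether either change would raise or lower the read-out on a compound that already shows a measurable effect. Going by these compounds, it also remains open whether an amine, a carboxylic acid or a longer chain on the saturated ring carbon would give any inhibition in this assay on this core.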